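The compounds below may be only part of what the source reports. "The series", "measured", "known", "first", "only" and "open" are said of these compounds alone.

In a functional assay on HeLa cells (Homo sapiens) for cytotoxicity, read by MTT assay, with a stated time of 72 h (a higher number here means a weaker inhibitor, a lower number a stronger inhibitor), compound 1, `CC(C)(C)c1nc2ccccc2n1C(=O)c1cccc2ccccc12`, gives > 10000 nM, which is a limit of the assay and not a number. Compound 2, `COc1ccc(-c2nc3ccccc3n2C(=O)c2cccc3ccccc23)cc1`, gives > 10000 nM, also a limit, so its position is known only as a limit. For the measured compounds named here, the series so far stands at the limit of > 10000 nM in this assay, at which 2 of the 2 values shown sit. Compound 3, `O=C(c1cccc2ccccc12)n1c(C2CCC2)nc2ccccc21`, differs from compound 2 by cyclobutyl in place of 4-methoxyphenyl on an aromatic carbon, between two ring nitrogen atoms. Going by the values given here, since the only measured step is a step that the two limits leave unreadable from compound 1 to compound 2, no size can be carried over from it, and no readable step is expected in this assay, in either direction. The expected outcome is a number no higher from compound 2 to compound 3 (the limit leaves the size open). For compound 3 the estimate is 10000 nM, with an expected range of 4000 nM to 20000 nM, and the result will most likely be reported only as a limit.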

Compound 3, half-maximal inhibitory concentration: > 10000 nM
Compound 3 ended at the assay's limit; the forecaster's own chance of this, stated with the estimate: 80%; the middle value lies on the limit itself.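

Compound 1, compound 2 and compound 3 all end at the assay's limit in this assay, so the steps among them cannot be read. The compounds shown leave open how far each lies beyond that limit, and whether any group at this carbon gives a readable value.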